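The source may report more compounds than this note shows. Statements on the series, on what has been measured and on what is new or still open speak of the compounds shown alone.

Measured compounds:
- compound 1, `O=C(O)CCc1nnc(C(=O)Nc2cccc(-c3ccco3)c2)s1`, in a functional assay on CHO cells for agonist activity at Free fatty acid receptor 1 (Homo sapiens), read by calcium flux; on this read-out lower numbers stand for an effect already at smaller amounts and higher numbers for an effect only at larger amounts of compound: 1640 nM
- compound 2, `Cc1ccccc1NC(=O)c1nnc(COc2ccc(CCC(=O)O)cc2)s1`, in this assay: 1520 nM

Both measured compounds share a central ring carrying an amide on one side and a chain that ends in a carboxylic acid on the other. Compound 2 has the lower of the two numbers, but the gap to compound 1 is within the scatter of repeated measurements, so the two values show no real difference between them.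

Compound 3, `Cc1ccc(NC(=O)c2nnc(COc3ccc(CCC(=O)O)cc3)s2)cc1`, is not yet measured. It is built from compound 2 by moving one methyl group around the ring attached to the amide nitrogen: 4-methylphenyl in place of 2-methylphenyl on an amide-type nitrogen. The atoms are the same; only the point where the methyl sits on that ring changes.

No comparison of this kind exists among the measured compounds, so there is no direct guide to its effect. Such a rearrangement of a single methyl on an outer ring often leaves the read-out close to where it was, and a step of no more than the usual scatter, in either direction, is expected from compound 2 to compound 3, a 1.0-fold lower number from compound 2 to compound 3 (0.01 log units; within the scatter). Compound 3 is therefore estimated at 1500 nM, with a likely range from 500 nM to 4500 nM.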

Compound 3, half-maximal effective concentration: 4300 nM
Compound 3: middle estimate off by 2.9-fold (0.46 log units), on the low side, and the stated range covers the measured number.
By their numbers in this assay, from the lowest: compounds 2 and 1 (each within the scatter of the next); then compound 3.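

Moving a single methyl group around the outer ring, with every atom kept, is enough to change the result in this assay: the switch to 4-methylphenyl on the amide-type nitrogen gives a 2.8-fold higher number from compound 2 to compound 3 (0.45 log units; beyond the scatter). Compound 1 and compound 2 differ in more than one place, so their similar numbers could say nothing about this ring on its own, whereas this pair shows that the read-out depends on where the methyl sits and that 2-methylphenyl gives the lower number of the two. This is one modest step in a single pair of compounds, and nothing available explains why the position of the methyl matters here.

The compounds shown leave open whether the methyl itself contributes anything, since a plain phenyl ring with no methyl would be needed to separate the benefit of 2-methylphenyl from any penalty of 4-methylphenyl. From the compounds shown here alone, it also remains open whether another small group, such as an ethyl, a methoxy or a chlorine, would give the same difference between these two positions.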